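The source may report more compounds than this note shows. Statements on the series, on what has been measured and on what is new or still open speak of the compounds shown alone.

Measured compounds in a functional assay on HepG2 cells (Homo sapiens) for antiproliferative activity, with a stated time of 72 h; a lower number here means that less compound is needed, a higher number that more compound is needed for the effect:

Compound 1, `COc1ccc(-c2cc(=O)c3c(OC)cc(OC)cc3[nH]2)cc1`: in this assay compound 1 gives > 31100 nM, which is a limit of the assay and not a number.
Compound 2, `COc1ccc(-c2[nH]c3cc(OC)cc(OC)c3c(=O)c2I)cc1`: in this assay compound 2 gives > 86200 nM, again a limit.
Compound 3, `COC(=O)c1cc(=O)c2c(OC)cc(OC)cc2n1S(=O)(=O)c1ccc(C)cc1`: in this assay compound 3 gives > 20000 nM, also a limit.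

Going by the values given here, compound 1 therefore stands only at a limit, and the other two values shown are limits as well, so no compound has a measured number. Among the compounds with values here, the one step between measured compounds, a step that the two limits leave unreadable from compound 1 to compound 2, cannot be read because both ends are limits.

Compound 4, `COc1ccc(-c2cc(=O)c3c(OC)cc(OC)cc3n2S(=O)(=O)c2ccc(C#N)cc2)cc1`, differs from compound 1 by (4-cyanophenyl)sulfonyl in place of hydrogen on an aromatic nitrogen. Within the data shown here, no measured step bears directly on this change. Among the measured compounds shown here, compound 3 carries a sulfonyl group on the aromatic nitrogen and sits at a limit, but no step from compound 1 to compound 3 is counted, so only its limit can be noted.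

For compound 4 the expectation is that this assay again reports a limit rather than a number, with the estimated step that the limit leaves unreadable from compound 1 to compound 4 formally no larger than the scatter. The estimate for compound 4 is 40000 nM, between 15000 nM and 100000 nM.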

Compound 4, half-maximal effective concentration: > 17200 nM
Compound 4 was reported as a limit; the forecaster's own chance of this, stated with the estimate: 85%; the middle value lies beyond the limit too.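

In this assay compound 4 gives > 17200 nM, a limit and not a number. Compound 1 also stands at a limit, and the step to compound 4 cannot be read. The compounds shown leave open whether (4-cyanophenyl)sulfonyl in place of hydrogen changes the activity at all in this assay.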